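A chloro step from compound 1 to compound 3

This account rests on a few compounds, and the source may have more. Where it says the series, first, only, none or still open, it means among the compounds named here.

Compound 1 `O=c1[nH]c(SCc2cc([N+](=O)[O-])cc([N+](=O)[O-])c2)nc2ccccc12` gives > 64000 nM (a limit)
Compound 2 `O=c1[nH]c(SCc2cc([N+](=O)[O-])cc([N+](=O)[O-])c2)nc2cccc(Cl)c12` gives > 64000 nM (a limit)

In an ADME assay on MRC5 cells (Homo sapiens) for cytotoxicity, read by neutral red uptake (on this read-out lower numbers stand for higher toxicity in this test and higher numbers for lower toxicity in this test), compound 1 gives > 64000 nM as a limit, not a number. Both measured compounds stand at the limit of > 64000 nM in this assay, at which 2 of the 2 values shown sit, and no exact value is known for either. Compound 3 `O=c1[nH]c(SCc2cc([N+](=O)[O-])cc([N+](=O)[O-])c2)nc2ccc(Cl)cc12` brings this change chloro in place of hydrogen on an aromatic carbon to the core of compound 1. Among the measured compounds shown here, the only measured step with the same kind of change is a step that the two limits leave unreadable from compound 1 to compound 2 and it gives no size. No step beyond the scatter is therefore expected in this assay for this change. The estimated step is a number no higher from compound 1 to compound 3 (the limit leaves the size open) in size. Compound 3 is expected at 64000 nM with an estimated range of 32000 nM to 128000 nM overall.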

Compound 3, half-maximal cytotoxic concentration: > 64000 nM
Compound 3: no number, only a limit (the forecaster's own chance of this, stated with the estimate: 85%); the middle value sits exactly at the limit.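

Compound 3, like compound 1 and compound 2, gives only a limit and no exact number, so no step between them can be read: the limit of > 64000 nM in this assay, at which 3 of the 3 values shown sit.

The compounds shown leave open whether chloro in place of hydrogen changes the result in this assay at all.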